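Trimming the 3,3-dimethylbutoxy chain to butoxy

This account rests on a few compounds, and the source may have more. Where it says the series, first, only, none or still open, it means among the compounds named here.

Compound 1 `CC(C)(C)CCOc1cccc(O)c1C(=O)/C=C/c1ccc(O)cc1`: 2380 nM
Compound 2 `O=C(/C=C/c1ccc(O)cc1)c1c(O)cccc1OCC1CCCCC1`: > 30000 nM (a limit)

For the measured compounds named here, in a functional assay on MDA-MB-231 cells (Homo sapiens) for antiproliferative activity, read by sulforhodamine B assay (on this read-out lower numbers stand for stronger inhibition of growth and higher numbers for weaker inhibition of growth), compound 1 gives 2380 nM, the only exact number so far. Compound 3 `CCCCOc1cccc(O)c1C(=O)/C=C/c1ccc(O)cc1` differs from it as follows: ethyl in place of tert-butyl on a saturated chain carbon, two bonds along the chain from an oxygen on an aromatic ring, which is butoxy in place of 3,3-dimethylbutoxy. Going by the values given here, only one measured step bears on this, an at least 12-fold higher number from compound 1 to compound 2 (1.10 log units; beyond the scatter). It is large and changes the same chain, but it adds a ring, so it gives no firm size for this change. A small rise in the number is expected, possibly none beyond the scatter. The expected step is a 1.7-fold higher number from compound 1 to compound 3 (0.23 log units; within the scatter). For compound 3 the estimate is 4000 nM, within 1200 nM to 18000 nM.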

Compound 3, concentration for 50% growth inhibition: > 30000 nM
Compound 3: no number, only a limit (the forecaster's own chance of this, stated with the estimate: 12%); middle value at least 7.5-fold (0.87 log units) away from the limit.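

In this assay, ethyl in place of tert-butyl, two bonds along the chain from the oxygen on the aromatic ring, gives an at least 12-fold higher number from compound 1 to compound 3 (1.10 log units; beyond the scatter). Losing growth inhibition at this position therefore needs no added ring: the shorter, unbranched butoxy chain of compound 3 also falls away. Compound 3 gives only a limit, > 30000 nM, and the step between compound 2 and compound 3 cannot be read: the limit of > 30000 nM in this assay, at which 2 of the 3 values shown sit.

From the compounds shown here alone, how large the loss truly is remains open. So does whether a longer unbranched chain, or an amine at the chain end, would restore growth inhibition.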